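This account rests on a few compounds, and the source may have more. Where it says the series, first, only, none or still open, it means among the compounds named here.

Compound 1 `COCC[C@H]1C[C@@H]1c1cncc(N2C[C@@H]3C[C@H]2CN3)c1`: "not determined" (no result reported)
Compound 2 `COCC[C@H]1C[C@@H]1c1cncc(N2CCCNCC2)c1`: 74%
Compound 3 `CN1CCCN(c2cncc(-c3cc(CCO)no3)c2)CC1`: "not determined" (no result reported)

Of these three, only compound 2 has a number in an assay on SH-EP1 cells for antagonist activity at Neuronal acetylcholine receptor; alpha4/beta2 (Homo sapiens), read by rubidium efflux, with stated times of 10 min and 5 min; a lower number here means a smaller maximal response, a higher number a larger maximal response. In this assay compound 2 gives 74%; compound 1 and compound 3 have no result reported, so compound 2 is the only reference point, and nothing can be said about how it compares with the other two.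

The next compound, compound 4 `COCC[C@@H]1C[C@H]1c1cncc(N2CCCNCC2)c1`, is the mirror image of compound 2: the two compounds have the same atoms and bonds and differ only in configuration as drawn: 2 of 2 stereo elements differ (all stereocentres are inverted: mirror images); a stereocentre at a saturated ring carbon is drawn R in compound 2 and S in compound 4; a stereocentre at a saturated ring carbon is drawn S in compound 2 and R in compound 4. Going by the values given here, no measured pair of mirror images is available here, so the size of the step from compound 2 to compound 4 in this assay cannot be read from the data. Mirror-image pairs can behave alike or very differently, so a step in either direction, or none beyond the scatter, is possible.

As an estimate, compound 4 is expected to give 60%, with a range from 25% to 95%. Among the compounds with values here, this expectation amounts to a step of a number 14 percentage points lower from compound 2 to compound 4 (beyond the scatter), kept wide because the only anchor is the single value of compound 2.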

Compound 4, largest response reached (reported as efficacy), in percent of the reference or control that the assay uses: 79%
Beside the measured number, compound 4's estimate is 19 percentage points below it; measured number inside the range.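

In this assay, inverting both stereocentres comes with a number 5 percentage points higher from compound 2 to compound 4 (within the scatter). Going by these compounds alone, this gives the first measured mirror-image pair, and at this position the two mirror images cannot be told apart by their maximal response, something the single value of compound 2 could not show. The comparison isolates configuration, with no other structural change involved: the fact that compounds 2 and 4 differ only in the configuration as drawn

Still open, going by these compounds, is whether inverting only one of the two stereocentres would leave the maximal response just as unchanged, since compound 2 and compound 4 differ at both. Also open, on these data alone, is whether the two mirror images would stay this close with another group in place of the chain ending in the methyl ether, such as a carboxylic acid or a primary amine.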